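An Ester Returns to a Lactone Scaffold

The source may hold more compounds than are shown below. What is called first, only, known or untested is meant among the compounds shown, and "the series" means these compounds.

Of the compounds shown here, three sharing a methylene lactone core have been measured in a functional assay on HL-60 cells (Homo sapiens) for cytotoxicity, read by trypan blue exclusion, with a stated time of 24 h; on this read-out higher numbers stand for weaker inhibition and lower numbers for stronger inhibition. Compound 1, `C=C1C(=O)O[C@@H]2CC(C)=C([C@@H](C)CCCOC(C)=O)[C@H](OC(C)=O)[C@H]12`, gives 35300 nM. Compound 3, `C=C1C(=O)O[C@H]2/C=C(\C)CC/C=C(\C)C[C@H](O)[C@@H]12`, gives 27400 nM. Compound 2, `C=C1C(=O)O[C@@H]2CC(C)=C([C@@H](C)CCCO)[C@H](O)[C@H]12`, received no number in this assay; for compound 2 only the limit > 100000 nM is reported. the limit of > 100000 nM in this assay, at which 1 of the 3 values shown sits, marks this reading as a limit of the assay rather than a measured value, so compound 2 stands at the edge of what the assay can report.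

Among the compounds with values here, no pair of measured compounds differs in a single place, so the move to compound 4, `C=C1C(=O)O[C@@H]2CC(C)=C([C@@H](C)CCCO)[C@H](OC(=O)C(C)CC)[C@H]12`, rests on the structural change alone: (sec-butyl)carbonyl in place of hydrogen on an oxygen on a saturated carbon. Read one bond further out, the change is hydroxy to ((sec-butyl)carbonyl)oxy. Compound 4 is expected to leave the limit and return to a measurable number, with a step of an at least 2.5-fold lower number from compound 2 to compound 4 (0.39 log units; beyond the scatter) estimated to be larger than the usual scatter and in the direction of stronger inhibition. The expected value for compound 4 in this assay is 40000 nM, within a range from 15000 nM to 100000 nM.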

Compound 4, half-maximal inhibitory concentration: 47100 nM
Estimate against measurement, compound 4: 1.2-fold (0.07 log units) below; low and high end bracket the measured number.
By their numbers in this assay, from the lowest: compounds 3, 1 and 4 (each within the scatter of the next). At a limit, above all of these: compound 2.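

In this assay, this oxygen on a saturated carbon proves to be a place where the attached group matters: putting (sec-butyl)carbonyl in place of hydrogen, so that hydroxy becomes ((sec-butyl)carbonyl)oxy, gives an at least 2.1-fold lower number from compound 2 to compound 4 (0.32 log units; beyond the scatter). The earlier compounds shown here could not show this, as no two of them differ in a single place, so nothing could be tied to one position. The size of this step is only a minimum, and the true gap could be larger, as the reading for compound 2 is a limit and not a number: the limit of > 100000 nM in this assay, at which 1 of the 4 values shown sits.

The compounds shown leave open whether the effect depends on the particular group that entered, and a benzoyl group, a longer straight acyl chain or an acyl group carrying an amine on this same oxygen would each test that. Also open is the real size of the step, and why the change acts at all, as nothing here separates the loss of the hydroxy hydrogen from the arrival of the new carbon atoms.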